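The compounds below may be only part of what the source reports. "The series", "measured", "known", "first", "only" and "open" are said of these compounds alone.

Compound 3, `COc1cc(Cl)cc(-c2nn(-c3cccc(NC(=O)Nc4ccc(Cl)c(Cl)c4)c3)cc2-c2ccncc2)c1`, gives 5.73% in a functional assay on CCRF-CEM cells (Homo sapiens) for inhibition, read by sulforhodamine B assay, with a stated time of 48 h, tested at 10 uM; a lower number here means a stronger effect, a higher number a weaker effect of the compound at the concentration tested. Among the three compounds measured so far it stands second highest. For the measured compounds named here, its nearest neighbour is compound 2, `COc1cc(Cl)cc(-c2nn(-c3cccc(NC(=O)Nc4cc(C(F)(F)F)cc(C(F)(F)F)c4)c3)cc2-c2ccncc2)c1`, which gives -22% in this assay; the furthest is compound 1, `COc1cc(Cl)cc(-c2nn(-c3cccc(NC(=O)c4ccc(Cl)c(Cl)c4)c3)cc2-c2ccncc2)c1`, which gives 59.2% in this assay, and the step of a number 53.5 percentage points lower from compound 1 to compound 3 (beyond the scatter) is the only one between compounds that differ in a single place.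

Compound 4, `COc1cc(Cl)cc(-c2nn(-c3cccc(NC(=O)Nc4cccc(C(F)(F)F)c4)c3)cc2-c2ccncc2)c1`, differs from compound 3 in one place: 3-(trifluoromethyl)phenyl in place of 3,4-dichlorophenyl on an amide-type nitrogen. Going by the values given here, no measured step changes the group on the amide-type nitrogen of the urea, so the step from compound 1 to compound 3 does not bear directly on it. What the numbers do show is that compound 2, carrying a 3,5-bis(trifluoromethyl)phenyl on that nitrogen, lies beyond the scatter below compound 3 with its 3,4-dichlorophenyl. Compound 4 carries a single trifluoromethyl on its phenyl, which sits between those two cases in substitution, so a step toward compound 2 is plausible but is not expected to exceed the scatter with confidence; the expected step is a number 10.7 percentage points lower from compound 3 to compound 4 (beyond the scatter). Compound 4 is therefore estimated at -5% in this assay, in a range from -40% to 30%.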

Compound 4, a percentage reported as activity, at one concentration (the size of the read-out at that concentration, not a potency): 3.34%
The estimate for compound 4 lay 8.3 percentage points below the measured number; the range from low to high includes it.
By their numbers in this assay, from the lowest: compound 2; then compounds 4 and 3 (each within the scatter of the next); then compound 1.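

In this assay, the change on the amide-type nitrogen from 3,4-dichlorophenyl to 3-(trifluoromethyl)phenyl gives a number 2.4 percentage points lower from compound 3 to compound 4 (within the scatter) and so does not separate these two groups at this position. For the compounds shown here, on the same aryl group, hydrogen in place of trifluoromethyl on an aromatic carbon gives a number 25.3 percentage points higher from compound 2 to compound 4 (beyond the scatter) and is the first single-place step on this ring that lies beyond the scatter, which sets compound 2 apart from compound 4 while compounds 3 and 4 stay together. The move with (3-(trifluoromethyl)phenyl)amino in place of 3,4-dichlorophenyl on a carbonyl carbon gives a number 55.9 percentage points lower from compound 1 to compound 4 (beyond the scatter) and adds a second large step from compound 1 to a urea, alongside a number 53.5 percentage points lower from compound 1 to compound 3 (beyond the scatter) with a different aryl group.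

It remains open whether a carboxylic acid or an amine on this phenyl, or a longer chain in its place on the urea nitrogen, would keep these read-outs, and a single tested concentration gives no potency for any of these compounds. Nothing in the data at hand accounts for these differences.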